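The compounds below may be only part of what the source reports. "The series", "measured", "known", "first", "only" and "open" are said of these compounds alone.

Measured compounds:
Compound 1 `COc1nc(N)nc2c1c(-c1cccs1)cn2[C@@H]1O[C@H](CO)[C@@H](O)[C@H]1O` — in an ADME assay on MRC5 cells (Homo sapiens), read by MTT assay, with a stated time of 72 h (on this read-out higher numbers stand for weaker inhibition and lower numbers for stronger inhibition), compound 1 gives > 100000 nM, which is a limit of the assay.
Compound 2 `Nc1nc2c(c(-c3cccs3)cn2[C@@H]2O[C@H](CO)[C@@H](O)[C@H]2O)c(=O)[nH]1` — in this assay compound 2 gives > 100000 nM, again a limit.
Compound 3 `COc1nc(N)nc2c1c(-c1ccoc1)cn2[C@@H]1O[C@H](CO)[C@@H](O)[C@H]1O` — in this assay compound 3 gives > 100000 nM, also a limit.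

Compound 1 and compound 3 differ in one place, (furan-3-yl in place of thiophen-2-yl on an aromatic carbon). The step that the two limits leave unreadable from compound 1 to compound 3 cannot be sized, because the limit of > 100000 nM in this assay, at which 3 of the 3 values shown sit, holds both ends. How the core of compound 2 differs from the core of compound 1 is not broken down here. Compound 4 `Nc1nc2c(c(-c3ccoc3)cn2[C@@H]2O[C@H](CO)[C@@H](O)[C@H]2O)c(=O)[nH]1` awaits measurement; it differs from compound 2 by furan-3-yl in place of thiophen-2-yl on an aromatic carbon, the same change as from compound 1 to compound 3, at the same place. In this assay the step that the limit leaves unreadable from compound 2 to compound 4 is expected to be negligible, because the limit of > 100000 nM in this assay, at which 3 of the 3 values shown sit, shows the same change leaving compound 1 and compound 3 both at the limit. Compound 4 is therefore estimated at 150000 nM, most likely reported only as a limit, within 50000 nM to 600000 nM.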

Compound 4, half-maximal inhibitory concentration: 86100 nM
Beside the measured number, compound 4's estimate is 1.7-fold (0.24 log units) above it; low and high end bracket the measured number.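

Carried to the other core, furan-3-yl in place of thiophen-2-yl gives an at least 1.1-fold lower number from compound 2 to compound 4 (0.06 log units; that floor lies within the scatter) in this assay, so a real shift is not established, although the true step may be larger than that floor. On the core of compound 1 the same change cannot be read, because both ends sit at a limit: the limit of > 100000 nM in this assay, at which 3 of the 4 values shown sit. The two cores therefore cannot be compared for this change, and nothing shows whether it acts alike or differently on them.

The compounds shown leave open how the number would respond to an amine or a carboxylic acid in place of furan-3-yl. They also leave open whether a longer chain on that aromatic carbon would bring any value clearly under the limit.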